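Tert-butyl for chloro on the benzyl ring

A few compounds are considered here, and "the series" means these few. Any claim that something is new, unique, unknown or untested is made for them only; others in the source may bear on it.

Among the three measured compounds, compound 3 `O=S(=O)(NCCCNCc1ccc(Cl)cc1)c1cc(C(F)(F)F)cc(C(F)(F)F)c1` gives the lowest number in a functional assay on A2780 cells (Homo sapiens) for inhibition, read by MTT assay, with a stated time of 72 h (a lower number here means a stronger inhibitor of growth, a higher number a weaker inhibitor of growth), at 1800 nM. Compound 2 `O=S(=O)(NCCCCNCc1ccc(Br)cc1)c1cc(C(F)(F)F)cc(C(F)(F)F)c1` gives 2100 nM, and the step of a 1.2-fold lower number from compound 2 to compound 3 (0.07 log units; within the scatter) lies within the scatter. Compound 1 `CC(C)(C)c1ccc(CNCCNS(=O)(=O)c2cc(C(F)(F)F)cc(C(F)(F)F)c2)cc1` gives 14000 nM, the highest of the three. Compound 4 `CC(C)(C)c1ccc(CNCCCNS(=O)(=O)c2cc(C(F)(F)F)cc(C(F)(F)F)c2)cc1` is compound 3 with tert-butyl in place of chloro on an aromatic carbon. Going by the values given here, no measured step isolates this change: compound 1 carries the same tert-butyl group as compound 4, but it differs from compound 3 in more than one place, so its higher number can only hint that the number may rise. Compound 4 is therefore expected to give a moderately higher number, a step of a 2.5-fold higher number from compound 3 to compound 4 (0.40 log units; beyond the scatter), with an estimate of 4500 nM and a range from 1500 nM to 14000 nM.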

Compound 4, concentration for 50% growth inhibition: 2900 nM
For compound 4 the middle estimate is 1.6-fold (0.19 log units) above the measured one; measured number inside the range.
By their numbers in this assay, from the lowest: compounds 3, 2 and 4 (each within the scatter of the next); then compound 1.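

In this assay, going by these compounds alone, tert-butyl in place of chloro gives a 1.6-fold higher number from compound 3 to compound 4 (0.21 log units; within the scatter), the first measured step that isolates this change. This aromatic carbon therefore takes tert-butyl, with four heavy atoms, in place of the single chlorine atom, with a step that stays within the scatter, which the comparison with compound 1, differing in more than one place, could not show. Nothing measured here offers a reason for this result. The compounds shown leave open whether methoxy or a carboxylic acid at this carbon would also stay within the scatter of compound 3.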